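Testing a Cyclobutyl Amide Against Two Inactive Anilides

The compounds below may be only part of what the source reports. "The series", "measured", "known", "first", "only" and "open" are said of these compounds alone.

Compound 1, `COc1ccccc1C(=O)Nc1cccc(NC(=O)c2ccc(Cl)cc2)c1`: > 30000 nM
Compound 2, `COc1ccccc1C(=O)Nc1cccc(NC(=O)c2ccco2)c1`: > 30000 nM

In an in vitro functional assay on HEK293-A cells for antagonist activity at metabotropic glutamate receptor 5 (Rattus norvegicus), read by calcium flux (a lower number here means a stronger inhibitor, a higher number a weaker inhibitor), compound 1 gives > 30000 nM, which is a limit of the assay and not a measured number. Compound 2 gives > 30000 nM, likewise a limit. Both values sit at the same place: the limit of > 30000 nM in this assay, at which 2 of the 2 values shown sit. The step that the two limits leave unreadable from compound 1 to compound 2 therefore cannot be given a size or a direction.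

Compound 3, `COc1ccccc1C(=O)Nc1cccc(NC(=O)C2CCC2)c1`, is not yet measured. It differs from compound 1 by cyclobutyl in place of 4-chlorophenyl on a carbonyl carbon. The only measured step, a step that the two limits leave unreadable from compound 1 to compound 2, bears on this change but is unreadable, so no movement beyond the scatter can be supported from the numbers shown. Compound 3 is therefore expected to give about 30000 nM in this assay, with an expected range from 10000 nM to 100000 nM, most probably reported as a limit again. The expected step of a number no higher from compound 1 to compound 3 (the limit leaves the size open) is thus none beyond the scatter.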

Compound 3, half-maximal inhibitory concentration: > 30000 nM
Compound 3: only a limit was reported; the forecaster's own chance of this, stated with the estimate: 85%; the middle value lies on the limit itself.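

In this assay compound 3 gives > 30000 nM, which is a limit of the assay and not a number. The steps linking compound 3 to compound 1 and compound 2 therefore cannot be read: the limit of > 30000 nM in this assay, at which 3 of the 3 values shown sit. The compounds shown leave open how strongly each one inhibits, and whether the group on this carbonyl carbon matters at all.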